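The source may hold more compounds than are shown below. What is called first, only, known or untested is meant among the compounds shown, and "the series" means these compounds.

Three compounds have been measured in a functional assay on MCF7 cells (Homo sapiens) for antiproliferative activity, read by MTT assay, with a stated time of 48 h; on this read-out higher numbers stand for weaker inhibition and lower numbers for stronger inhibition:

- Compound 1 `Oc1ccc2cc1Oc1ccc(cc1)CCc1ccc(CN3CCCCC3)c(O)c1-c1ccc(cc1O)CC2`: 5070 nM
- Compound 2 `CCCCN(CCCC)Cc1ccc2c(c1O)-c1ccc(cc1O)CCc1ccc(O)c(c1)Oc1ccc(cc1)CC2`: > 20000 nM, a limit
- Compound 3 `Nc1cc2cc(c1O)Oc1ccc(cc1)CCc1cccc(O)c1-c1ccc(cc1O)CC2`: > 20000 nM, a limit

Compound 3 has no number on this assay, only the limit > 20000 nM. The same limit applies to compound 2, so (the limit of > 20000 nM in this assay, at which 2 of the 3 values shown sit). Compound 1 alone has a measured number, 5070 nM.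

The next compound, compound 4 `CC(=O)Nc1cc2cc(c1O)Oc1ccc(cc1)CCc1cccc(O)c1-c1ccc(cc1O)CC2`, carries one change from compound 3. This is acetyl in place of hydrogen on a nitrogen on an aromatic ring, or amino to acetamido: acetyl in place of hydrogen on a nitrogen on an aromatic ring.

Among the measured compounds shown here, the only measured step is an at least 3.9-fold higher number from compound 1 to compound 2 (0.59 log units; beyond the scatter). It replaces piperidin-1-yl with dibutylamino on a saturated chain carbon, which is a different change at a different place, so it gives no direct measure of what acetyl on this nitrogen will do. For the measured compounds named here, no measured pair tests that change, and compound 3 offers only a limit as a starting point.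

With compound 3 at > 20000 nM, no step beyond the scatter is expected on this assay, and the assay may well report a limit again. The expected step is a number no higher from compound 3 to compound 4 (the limit leaves the size open). The estimate for compound 4 is 20000 nM, with an expected range of 9000 nM to 40000 nM.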

Compound 4, half-maximal inhibitory concentration: > 20000 nM
Compound 4 was reported as a limit; the forecaster's own chance of this, stated with the estimate: 65%; the middle value sits exactly at the limit.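

In this assay compound 4 gives > 20000 nM, which is a limit. Compound 3 stands at a limit as well, so no step can be read between compound 3 and compound 4. The compounds shown leave open what acetyl in place of hydrogen on a nitrogen on an aromatic ring does in this assay, with no measured number on either side of that change.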